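The compounds below may be only part of what the source reports. "The series", "measured", "known", "first", "only" and "open" are said of these compounds alone.

Measured so far:
compound 1 `Cn1c(COc2cccc(C(=O)O)c2)nc2cnc(Oc3ccc(Cl)c(F)c3)cc21`: 11.2 10^-6 cm/s
compound 2 `Cc1ccc(Oc2cc3c(cn2)nc(COc2cccc(C(=O)O)c2)n3C)cc1`: 6.8 10^-6 cm/s

In an ADME assay for permeability, using PAMPA, with a stated time of 4 h (a higher number here means that the compound crosses the layer faster, a lower number that the compound crosses the layer more slowly), compound 1 gives 11.2 10^-6 cm/s and compound 2 gives 6.8 10^-6 cm/s; the two numbers lie within the scatter of each other, as the step of a 1.6-fold lower number from compound 1 to compound 2 (0.22 log units; within the scatter) shows. Compound 3 `Cn1c(COc2cccc(C(=O)O)c2)nc2cnc(Oc3ccc4c(c3)OCC4)cc21` differs from compound 2 by a group of 9 heavy atoms (8 carbon, 1 oxygen; one five-membered non-aromatic ring with 1 hetero atom, one six-membered aromatic ring of carbon only) in place of a group of 7 heavy atoms (7 carbon; one six-membered aromatic ring of carbon only), on an oxygen on an aromatic ring. Within the data shown here, the one step seen, a 1.6-fold lower number from compound 1 to compound 2 (0.22 log units; within the scatter), also swapped the group on that oxygen and stayed within the scatter, so no step beyond the scatter is expected in this assay here either. Compound 3 is therefore estimated at 6 10^-6 cm/s (range 3 10^-6 cm/s to 12 10^-6 cm/s), a step of a 1.1-fold lower number from compound 2 to compound 3 (0.05 log units; within the scatter).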

Compound 3, apparent permeability: 3.6 10^-6 cm/s
Estimate against measurement, compound 3: 1.7-fold (0.22 log units) above; the measured number falls inside the stated range.
By their numbers in this assay, from the lowest: compounds 3, 2 and 1 (each within the scatter of the next, the first and the last beyond it).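

In this assay, swapping the group on this oxygen now gives a step beyond the scatter, though a modest one: a 3.1-fold lower number from compound 1 to compound 3 (0.49 log units; beyond the scatter). The same entering group gives only a 1.9-fold lower number from compound 2 to compound 3 (0.28 log units; within the scatter), so it separates from the 4-chloro-3-fluorophenyl group but not from the 4-methylphenyl group. Nothing measured here gives a reason for this.

Still open, on these data alone, is how a group carrying an amine, or a longer open chain in place of these rings, would read on this oxygen in this assay.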